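Variation of the amide group on the shared quinazoline-free core

A few compounds are considered here, and "the series" means these few. Any claim that something is new, unique, unknown or untested is made for them only; others in the source may bear on it.

Two members of the series have been measured in an assay for binding affinity to Adrenergic receptor alpha-1 (Rattus norvegicus); on this read-out lower numbers stand for stronger inhibition and higher numbers for weaker inhibition. Compound 1 `COc1cc2nc(N3CCN(C(=O)/C=C/c4cccc(F)c4)CC3)nc(N)c2cc1OC` gives 20.9 nM. Among the compounds with values here, compound 2 `COc1cc2nc(N3CCN(C(=O)c4ccc5ccccc5c4)CC3)nc(N)c2cc1OC` gives 49 nM, the higher of the two numbers; the only step recorded is a 2.3-fold higher number from compound 1 to compound 2 (0.37 log units; beyond the scatter), where one group on the carbonyl carbon replaces another.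

Compound 3 `COc1cc2nc(N3CCN(C(=O)c4ccc(N=C=S)c(I)c4)CC3)nc(N)c2cc1OC` continues the variation at the same carbonyl carbon. The change from compound 2 is a group of 10 heavy atoms (7 carbon, 1 nitrogen, 1 sulfur, 1 iodine; one six-membered aromatic ring of carbon only) in place of a group of 10 heavy atoms (10 carbon; 2 six-membered aromatic rings of carbon only), on a carbonyl carbon; the entering group keeps a single aromatic ring but carries nitrogen, sulfur and iodine instead of the second carbon ring.

Within the data shown here, the one measured step bears on this only in that it shows the carbonyl substituent can shift this assay modestly without abolishing binding. Among the measured compounds shown here, no measured compound carries a substituted single ring at this position, so the direction is open. The expectation for compound 3 is a number close to that of compound 2, with the step of a 1.2-fold lower number from compound 2 to compound 3 (0.09 log units; within the scatter) not clearly beyond the scatter. Compound 3 is therefore estimated at 40 nM, within a range of 12 nM to 130 nM.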

Compound 3, half-maximal inhibitory concentration: 51.3 nM
Estimate against measurement, compound 3: 1.3-fold (0.11 log units) below; measured number inside the range.
By their numbers in this assay, from the lowest: compound 1; then compounds 2 and 3 (each within the scatter of the next).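

In this assay, the single aromatic ring carrying nitrogen, sulfur and iodine takes the place of naphthalen-2-yl with a 1.0-fold higher number from compound 2 to compound 3 (0.02 log units; within the scatter) as the result, so on this carbonyl carbon the second carbon ring is not needed to hold a number at this level. Set against the 2-(3-fluorophenyl)ethenyl group, the same entering group gives a 2.5-fold higher number from compound 1 to compound 3 (0.39 log units; beyond the scatter) and this step lies beyond the scatter, as does a 2.3-fold higher number from compound 1 to compound 2 (0.37 log units; beyond the scatter) for naphthalen-2-yl, which leaves compound 1 with the lowest number of the three. Nothing available accounts for the small difference between the two groups or for the larger gap to compound 1.

The compounds shown do not separate what the iodine and the part holding nitrogen and sulfur each contribute, as the two appear only together in compound 3. Also open, from the compounds shown here alone, is how a plain phenyl ring, a phenyl ring bearing an amine or a carboxylic acid, or a longer chain between the ring and the carbonyl would read at this position.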